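Predicting One Side-Chain Swap From Three Near-Equal Results

This account rests on a few compounds, and the source may have more. Where it says the series, first, only, none or still open, it means among the compounds named here.

Compound 1 `CSCC[C@H](NC(=O)CN(c1ncnc2c1ncn2C1CCCCO1)C1CC1)C(=O)OCc1ccccc1` gives 41% in a functional assay on the whole organism (Tail, strain ICR) with Mus musculus as the target, in the tail flick test, with a stated time of 60 min, at a dose of 25 umol/kg by the oral route; on this read-out higher numbers stand for a stronger effect at the one dose given and lower numbers for a weaker effect. Among the three measured compounds none separates from the others: compound 3 `O=C(CN(c1nc(Cl)nc2[nH]cnc12)C1CC1)N[C@@H](CO)C(=O)O` gives 39.8% and compound 2 `O=C(O)C[C@H](NC(=O)CN(c1nc(Cl)nc2[nH]cnc12)C1CC1)C(=O)O` gives 38.9%, both within the usual scatter of the number for compound 1. Among the compounds with values here, the single measured step, a number 0.9 percentage points higher from compound 2 to compound 3 (within the scatter), likewise stays within the scatter. Compound 4 `CC(C)C[C@H](NC(=O)CN(c1ncnc2c1ncn2C1CCCCO1)C1CC1)C(=O)OCc1ccccc1` differs from compound 1 by isopropyl in place of (methylsulfanyl)methyl on a saturated chain carbon, two bonds along the chain from an amide-type nitrogen and a carbonyl carbon. Within the data shown here, no measured step concerns this exchange, and the one step that is known, at a different place and with different groups, was small. The expected step of no change at the digits printed from compound 1 to compound 4 (within the scatter) is therefore none beyond the scatter. Compound 4 is estimated at 41%, with a range from 30% to 52%.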

Compound 4, a percentage reported as activity, at one dose (the size of the read-out at that dose, not a potency): 34.2%
Estimate against measurement, compound 4: 6.8 percentage points above, within the range that was stated.
By their numbers in this assay, from the lowest: compounds 4, 2, 3 and 1 (each within the scatter of the next).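

At this position, on a saturated chain carbon, two bonds along the chain from an amide-type nitrogen and a carbonyl carbon, isopropyl in place of (methylsulfanyl)methyl gives a number 6.8 percentage points lower from compound 1 to compound 4 (within the scatter). The exchange removes the sulfur atom and the one hydrogen-bond acceptor of the leaving group, yet the step stays inside the scatter. Nothing available explains the step. Going by these compounds, whether a primary amine or a longer alkyl chain at this carbon would give a step beyond the scatter remains open.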